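Cytotoxicity notes on compound 4 and its measured neighbours

The source may hold more compounds than are shown below. What is called first, only, known or untested is meant among the compounds shown, and "the series" means these compounds.

Measured compounds:
- Compound 1 `CCc1ccc2[nH]c(=O)c(CN(Cc3ccc(C(C)(C)C)cc3)Cc3ccc(F)c(F)c3)cc2c1`: > 33000 nM, a limit of the assay
- Compound 2 `Cc1ccc2[nH]c(=O)c(CN(Cc3cccc(F)c3)Cc3ccc4ccccc4c3)cc2c1`: > 5000 nM, a limit of the assay
- Compound 3 `Cc1ccc2[nH]c(=O)c(CN(Cc3ccc(C(N)=O)cc3)Cc3ccc(C(C)(C)C)cc3)cc2c1`: > 5000 nM, a limit of the assay

In a toxicity assay on MDCK cells (Canis lupus familiaris) for cytotoxicity, read by crystal violet staining, with a stated time of 48 h (a lower number here means that less compound is tolerated, a higher number that more compound is tolerated), compound 1 gives > 33000 nM, which is a limit of the assay and not a number. Compound 2 gives > 5000 nM in this assay, again only a limit. Compound 3 gives > 5000 nM in this assay, also a limit. Compound 1 therefore stands at the limit of > 33000 nM in this assay, at which 1 of the 3 values shown sits, whereas the other two values sit at the limit of > 5000 nM in this assay, at which 2 of the 3 values shown sit. Within the data shown here, none of the three compounds gives a number, and no pair among them differs in a single place, so there is no measured step in this assay to lean on.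

Compound 4 `CCc1ccc2[nH]c(=O)c(CN(Cc3ccc(C(C)(C)C)cc3)C(C)c3ccc(OC)c(Cl)c3)cc2c1` is derived from compound 1 by one change: 1-(3-chloro-4-methoxyphenyl)ethyl in place of 3,4-difluorobenzyl on an amine nitrogen. Among the measured compounds shown here, with no measured step in this assay, the step from compound 1 to compound 4 is expected to stay within the scatter, that is a number no higher from compound 1 to compound 4 (the limit leaves the size open), and a limit rather than a number is the more likely outcome. In this assay compound 4 is estimated at 33000 nM, with a range from 10000 nM to 100000 nM.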

Compound 4, half-maximal cytotoxic concentration: > 10000 nM
Compound 4: no number, only a limit (the forecaster's own chance of this, stated with the estimate: 70%); the middle value does not contradict the limit.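

In this assay compound 4 gives > 10000 nM, which is a limit of the assay. Compound 1 also stands at a limit, so no step can be read between compound 1 and compound 4. The compounds shown leave open whether 1-(3-chloro-4-methoxyphenyl)ethyl in place of 3,4-difluorobenzyl changes the half-maximal cytotoxic concentration at all.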